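Lengthening a saturated chain once more

This account rests on a few compounds, and the source may have more. Where it says the series, first, only, none or still open, it means among the compounds named here.

Three compounds share one core and differ only in the length of a saturated chain. In a functional assay, with a stated time of 30 min (on this read-out higher numbers stand for weaker inhibition and lower numbers for stronger inhibition), compound 1 `CCCCCCCCCCOc1cc(OC)c(Br)cc1C(C)=O` gives 35100000 nM, compound 2 `CCCCCCCCCCCCOc1cc(OC)c(Br)cc1C(C)=O` gives 29500000 nM and compound 3 `CCCCCCCCCCCCCCOc1cc(OC)c(Br)cc1C(C)=O` gives 16100000 nM. Compound 3 stands level with compound 2 within the scatter and apart only from compound 1.

Compound 4 `CCCCCCCCCCCCCCCCOc1cc(OC)c(Br)cc1C(C)=O` has not yet been measured. The change from compound 3 is ethyl in place of hydrogen on a saturated chain carbon, ten or more bonds along the chain from an oxygen on an aromatic ring, with ethyl in place of hydrogen on a saturated chain carbon, ten or more bonds along the chain from an oxygen on an aromatic ring.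

The closest guides are the two earlier ethyl changes, a 1.2-fold lower number from compound 1 to compound 2 (0.08 log units; within the scatter) and a 1.8-fold lower number from compound 2 to compound 3 (0.26 log units; within the scatter), both within the scatter. The butyl change, a 2.2-fold lower number from compound 1 to compound 3 (0.34 log units; beyond the scatter), is modest and lies just beyond it. That larger step leads to a lower number, so a slight drift the same way is expected in this assay, but nothing beyond the scatter. The expected step is a 1.3-fold lower number from compound 3 to compound 4 (0.13 log units; within the scatter). For compound 4 the estimated value is 12000000 nM, with an expected range from 6000000 nM to 24000000 nM.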

Compound 4, half-maximal inhibitory concentration: 6500000 nM
Estimate against measurement, compound 4: 1.8-fold (0.27 log units) above, within the range that was stated.
By their numbers in this assay, from the lowest: compound 4; then compounds 3, 2 and 1 (each within the scatter of the next, the first and the last beyond it).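

In this assay, among these compounds, the ethyl change on this saturated chain carbon now gives a step beyond the scatter for the first time, a 2.5-fold lower number from compound 3 to compound 4 (0.39 log units; beyond the scatter). Even so, this step cannot be firmly separated from the same change made on the shorter chain: the same change on two cores in this assay, a 1.2-fold lower number (0.08 log units; within the scatter) from compound 1 to compound 2 and a 2.5-fold lower number (0.39 log units; beyond the scatter) from compound 3 to compound 4, 2.1-fold (0.32 log units) apart, within the scatter of two such steps. The larger changes at this position point the same way, with hexyl giving a 5.4-fold lower number from compound 1 to compound 4 (0.73 log units; beyond the scatter) and butyl giving a 4.5-fold lower number from compound 2 to compound 4 (0.66 log units; beyond the scatter), although this butyl step also stays close to the earlier one: the same change on two cores in this assay, a 2.2-fold lower number (0.34 log units; beyond the scatter) from compound 1 to compound 3 and a 4.5-fold lower number (0.66 log units; beyond the scatter) from compound 2 to compound 4, 2.1-fold (0.32 log units) apart, within the scatter of two such steps.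

What a longer chain would give remains open, so the compounds shown do not reveal where the trend stops. Also open, as far as these compounds go, is how a carboxylic acid or an amine at the far end of the chain would compare with the plain saturated chain.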